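Trimming a pentyloxy chain to methoxy on a chromone sulfoxide

This account rests on a few compounds, and the source may have more. Where it says the series, first, only, none or still open, it means among the compounds named here.

In a functional assay on A549 cells (Homo sapiens) for cytotoxicity, with a stated time of 48 h (a higher number here means a weaker inhibitor, a lower number a stronger inhibitor), three compounds have been measured:
compound 1 `C[S+]([O-])/C=C/c1cc(=O)c2ccccc2o1` gives 1900 nM
compound 2 `CCCC(=O)Oc1ccc2oc(/C=C/[S+](C)[O-])cc(=O)c2c1` gives 2200 nM
compound 3 `CCCCCOc1ccc2oc(/C=C/[S+](C)[O-])cc(=O)c2c1` gives 1600 nM

Compound 3 sits within the scatter of both others: a 1.2-fold lower number from compound 1 to compound 3 (0.07 log units; within the scatter) and a 1.4-fold lower number from compound 2 to compound 3 (0.14 log units; within the scatter). Neither adding pentyloxy to the core nor swapping propylcarbonyl for pentyl on that oxygen moved this assay beyond its noise.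

Compound 4 `COc1ccc2oc(/C=C/[S+](C)[O-])cc(=O)c2c1` differs from compound 3 by hydrogen in place of butyl on a saturated chain carbon bound to an oxygen on an aromatic ring. Among the measured compounds shown here, the steps that bear on it are the two above, both within the scatter. Shortening the chain is therefore expected to leave this assay essentially unchanged, with a 1.1-fold higher number from compound 3 to compound 4 (0.03 log units; within the scatter). Compound 4 is estimated at 1700 nM, between 850 nM and 3400 nM.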

Compound 4, half-maximal inhibitory concentration: 1600 nM
For compound 4 the middle estimate is 1.1-fold (0.03 log units) above the measured one; low and high end bracket the measured number.
By their numbers in this assay, from the lowest: compounds 3, 4, 1 and 2 (each within the scatter of the next).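

In this assay, methoxy and pentyloxy read alike on this aromatic carbon (no change at the digits printed from compound 3 to compound 4 (within the scatter)), so the short chain and the long one cannot be told apart here. Methoxy also stays within the scatter of the butyrate-free comparisons available, the propylcarbonyl ester (a 1.4-fold lower number from compound 2 to compound 4 (0.14 log units; within the scatter)) and the unsubstituted core (a 1.2-fold lower number from compound 1 to compound 4 (0.07 log units; within the scatter)). No supporting measurement accounts for this flat reading. The compounds shown leave open whether an amine or a carboxylic acid at the end of this chain, or a chain longer than pentyl, would give a step beyond the scatter.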